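This account rests on a few compounds, and the source may have more. Where it says the series, first, only, none or still open, it means among the compounds named here.

Measured compounds:
compound 1 `Cc1ccccc1Nc1nc(Nc2ccc(N3CCN(C)CC3)cn2)ncc1Cl`, in a functional assay on MCF7 cells (Homo sapiens) for inhibition, read by CCK-8 assay, with a stated time of 48 h (a higher number here means a weaker inhibitor of growth, a lower number a stronger inhibitor of growth), compound 1 gives 5210 nM
compound 2 `Cc1ccccc1Nc1nc(Nc2ccc(N3CCCCC3)cn2)ncc1Cl`, compound 2 gives 21400 nM
compound 3 `Cc1ccccc1Nc1nc(Nc2ccc(N3CCCN(C)CC3)cc2)ncc1Cl`, compound 3 gives 4290 nM

Compound 1 stands second highest of the three numbers; compound 3 sits nearest, within the scatter, and compound 2 furthest. Within the data shown here, the only measured step, a 4.1-fold higher number from compound 1 to compound 2 (0.61 log units; beyond the scatter), alters the ring on the aromatic carbon and leaves the anilino end untouched. Compound 4 `CC(C)c1cccc(Nc2nc(Nc3ccc(N4CCN(C)CC4)cn3)ncc2Cl)c1` differs from compound 1 at that other end: 3-isopropylphenyl in place of 2-methylphenyl on a nitrogen on an aromatic ring. Among the measured compounds shown here, no measured step touches this part of the shared core, so the change has no direct precedent here; the scale of the single step seen elsewhere suggests at most a modest shift, direction unknown. Compound 4 is expected near 5500 nM, between 1500 nM and 20000 nM, an expected 1.1-fold higher number from compound 1 to compound 4 (0.02 log units; within the scatter) without clear direction.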

Compound 4, concentration for 50% growth inhibition: 8640 nM
Compound 4: middle estimate off by 1.6-fold (0.20 log units), on the low side; measured number inside the range.
By their numbers in this assay, from the lowest: compounds 3, 1 and 4 (each within the scatter of the next); then compound 2.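

In this assay, among these compounds, the exchange of 2-methylphenyl for 3-isopropylphenyl gives a 1.7-fold higher number from compound 1 to compound 4 (0.22 log units; within the scatter) and so stays within the scatter, the first reading at this end of the shared core. Among the compounds shown here, the only step beyond the scatter remains a 4.1-fold higher number from compound 1 to compound 2 (0.61 log units; beyond the scatter) at the other end. No measured evidence bears on this result.

The compounds shown do not separate the change of alkyl group from its change of place on the phenyl ring. Also open, going by these compounds, is how an amine or a carboxylic acid on that ring would read.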